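This account rests on a few compounds, and the source may have more. Where it says the series, first, only, none or still open, it means among the compounds named here.

Compound 1 `CC(C)c1ccccc1NC(=O)N[C@H](C)c1ccccc1`, compound 2 `CC(C)c1cccc(NC(=O)N[C@H](C)c2ccccc2)c1` and compound 3 `C[C@@H](NC(=O)Nc1ccccc1C(F)(F)F)c1ccccc1` were run in an ADME assay on the whole organism with Oryza sativa as the target, tested at 0.1 uM; on this read-out higher numbers stand for a weaker effect at the one concentration tested and lower numbers for a stronger effect. In that read-out compound 1 gives 103%, compound 3 gives 99%, and compound 2 gives 74%. Compound 1 and compound 3 share a core and differ by trifluoromethyl in place of isopropyl on an aromatic carbon; the step of a number 4 percentage points lower from compound 1 to compound 3 (within the scatter) lies within the scatter. Compound 2 is built from the same atoms as compound 1, joined differently, and the difference between the two cores is not broken down here. Its number is the lowest of the three, beyond the scatter against both compound 3 and compound 1. Compound 4 `C[C@@H](NC(=O)Nc1cccc(C(F)(F)F)c1)c1ccccc1` has not yet been measured; it is related to compound 2 by trifluoromethyl in place of isopropyl on an aromatic carbon. Among the measured compounds shown here, this is the same kind of change as the one between compound 1 and compound 3, though the place differs: ortho to a large group in the first pair, meta to a large group in the second. A step of similar size is expected in this assay, because the earlier one a number 4 percentage points lower from compound 1 to compound 3 (within the scatter) stayed within the scatter. For compound 4 the expected step is a number 2 percentage points lower from compound 2 to compound 4 (within the scatter). Compound 4 is therefore estimated at 72%, between 55% and 90%.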

Compound 4, a percentage reported as activity, at one concentration (the size of the read-out at that concentration, not a potency): 82%
The estimate for compound 4 lay 10 percentage points below the measured number; low and high end bracket the measured number.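

In this assay the new step is a number 8 percentage points higher from compound 2 to compound 4 (within the scatter), so on this core too, trifluoromethyl in place of isopropyl leaves the number within the scatter. Set beside the earlier step, the change reads the same on the two cores, and in this small set it carries from one to the other without a difference that can be told apart: the same change on two cores in this assay, a number 4 percentage points lower (within the scatter) from compound 1 to compound 3 and a number 8 percentage points higher (within the scatter) from compound 2 to compound 4, 12 percentage points apart, within the scatter of two such steps
Among the compounds shown here, this rests on only two pairs, so it does not show that the exchange would behave the same way on any other core, and a small real difference between the two steps could still lie hidden in the scatter.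

The compounds shown leave open how a nitrile, a methoxy group or a carboxylic acid would read in place of isopropyl on this aromatic carbon. They also leave open whether the two steps would still match at any concentration other than the single one tested.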